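Replacing chloro with methyl on the shared core

A few compounds are considered here, and "the series" means these few. Any claim that something is new, unique, unknown or untested is made for them only; others in the source may bear on it.

In an in vivo ADME assay on the whole organism (strain Sprague-Dawley) for metabolic stability, with Rattus norvegicus as the target (on this read-out higher numbers stand for a longer-lived compound and lower numbers for a shorter-lived compound), compound 1 (`CC(C)C1(c2ccc(-c3ccc4ccccc4c3)[nH]c2=O)OC(=O)NC1=O`) gives 3.5 h and compound 2 (`CC(C)C1(c2cc(Cl)c(-c3ccc4ccccc4c3)[nH]c2=O)OC(=O)NC1=O`) gives 5.3 h so the two values lie within the scatter of each other. For the measured compounds named here, compound 2 therefore stands level with compound 1 on the numbers so far. Compound 3 (`Cc1cc(C2(C(C)C)OC(=O)NC2=O)c(=O)[nH]c1-c1ccc2ccccc2c1`) differs from compound 2 by methyl in place of chloro on an aromatic carbon. Going by the values given here, no measured compound carries this methyl, so the data hold no direct precedent for it. Among the compounds with values here, the one measured step that bears on the change is the replacement of hydrogen by chloro, which gave a 1.5-fold higher number from compound 1 to compound 2 (0.18 log units; within the scatter) in this assay and so did not move the value beyond the scatter. Within the data shown here, with compound 1 at 3.5 h and compound 2 at 5.3 h as the only guides, a step of similar small size is expected here. The expected change is a 1.2-fold lower number from compound 2 to compound 3 (0.07 log units; within the scatter) and no direction beyond the scatter is anticipated. The estimate for compound 3 is 4.5 h as the expected value (expected range 2.3 h to 8.5 h).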

Compound 3, half-life: 6.6 h
Beside the measured number, compound 3's estimate is 1.5-fold (0.17 log units) below it, and the stated range covers the measured number.
By their numbers in this assay, from the lowest: compounds 1, 2 and 3 (each within the scatter of the next).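

At this position, on an aromatic carbon two atoms from the ring nitrogen, the shared core has now carried hydrogen, chloro and methyl, and in this assay the exchange of chloro for methyl gives a 1.2-fold higher number from compound 2 to compound 3 (0.10 log units; within the scatter) and so does not separate the two groups. The comparison with hydrogen gives a 1.9-fold higher number from compound 1 to compound 3 (0.28 log units; within the scatter) and also stays within the scatter, so none of the three groups has been shown to shift the half-life of this series, although the step from hydrogen to methyl is the largest of the three read so far. Nothing measured here speaks to why these steps are as small as they are.

On these data alone, whether an amine, a methoxy group or a nitrile on this same carbon would give a step beyond the scatter remains open. Also open, as far as these compounds go, is whether methyl and chloro would still give numbers this close together once another part of the shared core carries a different group, such as a longer chain.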